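Ethynyl in Place of Sulfamoyl: Estimating Compound 3

A few compounds are considered here, and "the series" means these few. Any claim that something is new, unique, unknown or untested is made for them only; others in the source may bear on it.

Compound 1, `COc1cc(-c2noc(-c3cccc(NS(=O)(=O)c4ccc(NC(C)=O)cc4)c3)n2)ccc1NC(=O)c1cccnc1`: > 10000 nM
Compound 2, `NS(=O)(=O)c1ccc(NC(=O)Nc2cccc(-c3nc(-c4ccc(NC(=O)c5cccnc5)cc4Cl)no3)c2)cc1`: > 10000 nM

Both measured values are limits of the assay rather than numbers. In a functional assay on MDA-MB-231 cells (Homo sapiens) for antiproliferative activity, read by MTT assay, with a stated time of 72 h (on this read-out higher numbers stand for weaker inhibition and lower numbers for stronger inhibition), compound 1 gives > 10000 nM, a limit. In this assay compound 2 gives > 10000 nM, again a limit. For the measured compounds named here, compound 2 therefore stands where the only other measured compound stands: at the limit of > 10000 nM in this assay, at which 2 of the 2 values shown sit, with no number to separate the two.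

Compound 3, `C#Cc1ccc(NC(=O)Nc2cccc(-c3nc(-c4ccc(NC(=O)c5cccnc5)cc4Cl)no3)c2)cc1`, differs from compound 2 by ethynyl in place of sulfamoyl on an aromatic carbon. Going by the values given here, no step between measured compounds is available to guide the size of this change. With both known values at the limit, the step from compound 2 to compound 3 is expected to be an at least 1.2-fold lower number from compound 2 to compound 3 (0.09 log units; that floor lies within the scatter), with a modest chance of a measurable number appearing. The estimate for compound 3 in this assay is 8000 nM, within 1500 nM to 30000 nM.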

Compound 3, half-maximal inhibitory concentration: > 10000 nM
Compound 3: only a limit was reported; the forecaster's own chance of this, stated with the estimate: 55%; middle value at least 1.2-fold (0.09 log units) from the limit.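

In this assay compound 3 gives > 10000 nM, a limit and not a number. For the compounds shown here, compound 2 also stands at a limit, so no step between compound 2 and compound 3 can be read. The compounds shown leave open what ethynyl in place of sulfamoyl changes, as all share one limit: the limit of > 10000 nM in this assay, at which 3 of the 3 values shown sit.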